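The source may hold more compounds than are shown below. What is called first, only, known or untested is meant among the compounds shown, and "the series" means these compounds.

Three compounds sharing one core were tested in a functional assay on A549 cells (Homo sapiens) for antiproliferative activity, read by MTT assay, with a stated time of 72 h; on this read-out higher numbers stand for weaker inhibition and lower numbers for stronger inhibition. Compound 1 `CCN(C)C(=N)NC(=N)Nc1ccc(C(F)(F)F)cc1` gives 4100 nM in this assay. Compound 2 `CC(C)NC(=N)NC(=N)Nc1ccc(F)c(F)c1` gives 5200 nM, and compound 3 `CC(C)CNC(=N)NC(=N)Nc1ccc(F)cc1F` gives 3600 nM. Among these three numbers compound 1 holds the second highest; its nearest neighbour is compound 3 and its furthest is compound 2, yet both gaps lie within the usual scatter of repeated measurements, so the three compounds cannot be told apart on this read-out.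

Compound 4 `CCN(CC)C(=N)NC(=N)Nc1ccc(C(F)(F)F)cc1` has not yet been measured. It differs from compound 1 in a single place: methyl in place of hydrogen on a saturated chain carbon bound to an amine nitrogen. For the measured compounds named here, no measured pair in the set shows this particular change, so there is no observed step to lean on. Since the change is small and compound 1 sits at 4100 nM, the step of a 1.0-fold lower number from compound 1 to compound 4 (0.01 log units; within the scatter) is expected to be none beyond the scatter. Compound 4 is therefore estimated at 4000 nM, with a likely range from 2000 nM to 8000 nM.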

Compound 4, half-maximal inhibitory concentration: 3700 nM
For compound 4 the middle estimate is 1.1-fold (0.03 log units) above the measured one; the measured number falls inside the stated range.
By their numbers in this assay, from the lowest: compounds 3, 4, 1 and 2 (each within the scatter of the next).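

For the compounds shown here, compound 4 gives the first direct reading at this position, where the earlier compounds offered no pair differing in one place. In this assay, going from ethyl(methyl)amino to diethylamino gives a 1.1-fold lower number from compound 1 to compound 4 (0.04 log units; within the scatter), so the read-out does not separate the two compounds, and this position accepts the extra methyl on the saturated chain carbon bound to the amine nitrogen without a measurable difference. Nothing at hand speaks to the reason for this outcome.

Going by these compounds, this single pair carries trifluoromethyl on the shared core, so it remains open whether the same change would read alike alongside the fluorine-bearing compounds. On these data alone, it also remains open whether a longer chain such as butyl, or a hydroxyl group at the end of the ethyl chain, would stay within the scatter of compound 4.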